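Acetyl for 1-methylethenyl on the compound 1 core

This account rests on a few compounds, and the source may have more. Where it says the series, first, only, none or still open, it means among the compounds named here.

Compound 1 `C=C(C)c1ccccc1OC(C)C1=NCCN1` gives the lowest number of the three measured in an assay on CHO cells for displacement of a labelled ligand from Alpha-2B adrenergic receptor (Homo sapiens) (a lower number here means a stronger inhibitor, a higher number a weaker inhibitor), at 871 nM. Compound 2 `CC(Oc1ccccc1OC1CC1)C1=NCCN1` gives 1050 nM in this assay, and the step of a 1.2-fold higher number from compound 1 to compound 2 (0.08 log units; within the scatter) lies within the scatter. Compound 3 `CC(Oc1ccccc1C=O)C1=NCCN1` gives 2090 nM, and the step of a 2.4-fold higher number from compound 1 to compound 3 (0.38 log units; beyond the scatter) is modest but beyond the scatter; between compound 2 and compound 3 the step of a 2.0-fold higher number from compound 2 to compound 3 (0.30 log units; within the scatter) stays within the scatter.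

Compound 4 `CC(=O)c1ccccc1OC(C)C1=NCCN1` differs from compound 1 in one place: acetyl in place of 1-methylethenyl on an aromatic carbon. Going by the values given here, the step that bears most on this change is the one to compound 3, where a carbonyl-bearing group also replaced the 1-methylethenyl group and gave a 2.4-fold higher number from compound 1 to compound 3 (0.38 log units; beyond the scatter); the step to compound 2 shows that not every replacement at this carbon moves the number. Compound 4 is therefore expected to sit between compound 1 and compound 3, with an estimated step of a 1.7-fold higher number from compound 1 to compound 4 (0.24 log units; within the scatter). The estimate for compound 4 in this assay is 1500 nM, with a range from 700 nM to 3500 nM.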

Compound 4, inhibition constant: 6170 nM
For compound 4 the middle estimate is 4.1-fold (0.61 log units) below the measured one, and the stated range ends below it.
By their numbers in this assay, from the lowest: compounds 1, 2 and 3 (each within the scatter of the next, the first and the last beyond it); then compound 4.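

In this assay acetyl stands apart from every other group at this aromatic carbon, with a 7.1-fold higher number from compound 1 to compound 4 (0.85 log units; beyond the scatter) and a 5.9-fold higher number from compound 2 to compound 4 (0.77 log units; beyond the scatter) as its steps from the two compounds without a carbonyl at this position. A carbonyl-bearing group here does not settle the number by itself, since methyl in place of hydrogen on the carbonyl carbon gives a 3.0-fold higher number from compound 3 to compound 4 (0.47 log units; beyond the scatter) and so separates the two carbonyl compounds beyond the scatter. Acetyl and 1-methylethenyl have the same count of heavy atoms, so the largest step in this set comes with no change in that count. On these data alone, whether a propanoyl group, a 1-hydroxyethyl group or a carboxylic acid at this carbon would follow acetyl or formyl stays open. The compounds shown offer no measurement that accounts for the shift.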